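The source may hold more compounds than are shown below. What is called first, only, known or untested is meant among the compounds shown, and "the series" means these compounds.

Measured compounds:
compound 1 `COc1ccc(/C=C2\S/C(=N\c3csc(-c4ccc(Cl)cc4)c3)NC2=O)cc1` gives 3800 nM
compound 2 `CN(C)c1ccc(/C=C2\S/C(=N\c3csc(-c4ccc(Cl)cc4)c3)NC2=O)cc1` gives 1500 nM

Among these two numbers compound 2 holds the lower one in a functional assay on HT-29 cells (Homo sapiens) for cytotoxicity, read by MTT assay, with a stated time of 72 h; on this read-out lower numbers stand for stronger inhibition and higher numbers for weaker inhibition; its nearest neighbour is compound 1, and the step of a 2.5-fold lower number from compound 1 to compound 2 (0.40 log units; beyond the scatter) separates them. Compound 3 `O=C1N/C(=N/c2csc(-c3ccc(Cl)cc3)c2)S/C1=C\c1ccc(Br)cc1` is the next compound to be examined in this assay. Relative to compound 2 the change is bromo in place of dimethylamino on an aromatic carbon.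

For the measured compounds named here, only one measured step bears on this change: the replacement of methoxy by dimethylamino at the same place, which brought the number down by a 2.5-fold lower number from compound 1 to compound 2 (0.40 log units; beyond the scatter). Going by the values given here, no measured compound carries bromo at that position, so the direction for bromo is not fixed by the data. Since the dimethylamino group that accompanied the lower number now leaves, compound 3 is expected to return toward the region of compound 1, a step of a 1.9-fold higher number from compound 2 to compound 3 (0.27 log units; within the scatter). Compound 3 is therefore estimated at 2800 nM, within a range from 900 nM to 9000 nM.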

Compound 3, half-maximal inhibitory concentration: 2000 nM
Compound 3: middle estimate off by 1.4-fold (0.15 log units), on the high side; the range from low to high includes it.
By their numbers in this assay, from the lowest: compounds 2, 3 and 1 (each within the scatter of the next, the first and the last beyond it).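

In this assay, bromo on this aromatic carbon gives a 1.3-fold higher number from compound 2 to compound 3 (0.12 log units; within the scatter) and a 1.9-fold lower number from compound 1 to compound 3 (0.28 log units; within the scatter), so compound 3 cannot be separated from either neighbour, even though compound 1 and compound 2 lie beyond the scatter of each other. The position therefore takes a single bromine atom, with no hydrogen-bond acceptor, in place of the 3 heavy atoms of dimethylamino without a step beyond the scatter, something the earlier pair could not show. Nothing available explains these numbers.

The compounds shown leave open whether any group on this carbon moves the number much further than the small span seen so far. A carboxylic acid, a primary amine or a plain hydrogen at this place would test that.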